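Swapping the sugar on a triazole for a protected diol

The source may report more compounds than this note shows. Statements on the series, on what has been measured and on what is new or still open speak of the compounds shown alone.

Measured compounds:
- Compound 1, `O=C1c2c[n+]([O-])c3ccccc3c2C(=O)c2c1c1ccccc1n2Cc1cn([C@H]2C[C@H](O)[C@@H](CO)O2)nn1`: 390 nM
- Compound 2, `O=C1c2c[n+]([O-])c3ccccc3c2C(=O)c2[nH]c3ccccc3c21`: 660 nM

In a functional assay on A-375 cells (Homo sapiens) for cytotoxicity, read by MTT assay, with a stated time of 72 h (a lower number here means a stronger inhibitor, a higher number a weaker inhibitor), compound 1 gives 390 nM. Compound 2, which carries no group on the ring nitrogen of the shared core, gives 660 nM in this assay; the two numbers lie within the usual scatter of each other, so compound 1 cannot be set apart from compound 2 on these data.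

Compound 3, `CC1(C)OCC(Cn2cc(Cn3c4c(c5ccccc53)C(=O)c3c[n+]([O-])c5ccccc5c3C4=O)nn2)O1`, is the one not yet measured. It differs from compound 1 in a single place: (2,2-dimethyl-1,3-dioxolan-4-yl)methyl in place of 4-hydroxy-5-(hydroxymethyl)oxolan-2-yl on an aromatic nitrogen.

Going by the values given here, no step between two measured compounds is known for this kind of change. Since compound 1 and compound 2 sit within the scatter of each other, the account expects the step of a 1.3-fold higher number from compound 1 to compound 3 (0.11 log units; within the scatter) in this assay to be small, with no direction that can be told from the data. Compound 3 is therefore estimated at 500 nM, within a range from 150 nM to 1600 nM.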

Compound 3, half-maximal inhibitory concentration: 330 nM
Compound 3: middle estimate off by 1.5-fold (0.18 log units), on the high side; the range from low to high includes it.
By their numbers in this assay, from the lowest: compounds 3, 1 and 2 (each within the scatter of the next).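

In this assay, putting (2,2-dimethyl-1,3-dioxolan-4-yl)methyl in place of 4-hydroxy-5-(hydroxymethyl)oxolan-2-yl on an aromatic nitrogen of the five-membered aromatic ring with 3 nitrogen gives a 1.2-fold lower number from compound 1 to compound 3 (0.07 log units; within the scatter). At this place, then, a group with 0 hydrogen-bond donors and no defined stereocentres stands level with one that has 2 hydrogen-bond donors and 3 defined stereocentres, so neither feature is shown to matter for this read-out. Nothing available bears on why the two groups match.

Going by these compounds, both groups have 8 heavy atoms and an oxygen-containing five-membered non-aromatic ring, so it stays open whether an amine, a carboxylic acid or a longer alkyl chain at this place would give a number beyond the scatter. On these data alone, whether the match between compound 1 and compound 3 holds beyond this assay also stays open.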